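A few compounds are considered here, and "the series" means these few. Any claim that something is new, unique, unknown or untested is made for them only; others in the source may bear on it.

Measured in an ADME assay on HEp-2 cells (Homo sapiens) for cytotoxicity; on this read-out lower numbers stand for higher toxicity in this test and higher numbers for lower toxicity in this test:
- compound 1 `CC(C)CCn1c(Cn2c(=O)n(C(C)C)c3ccccc32)nc2cc(CNC3CC3)ccc21`: 17200 nM
- compound 2 `CC(C)CCn1c(Cn2c(=O)n(C(C)C)c3ccccc32)nc2cc(-c3nn[nH]n3)ccc21`: 2000 nM

Of these two numbers, the lower belongs to compound 2, at 2000 nM, and the gap to the other lies beyond the scatter. The next structure, compound 3 `CC(C)CCn1c(Cn2c(=O)n(C(C)C)c3ccccc32)nc2cc(C(=O)N(C)C)ccc21`, keeps the shared core and carries dimethylcarbamoyl in place of 2H-tetrazol-5-yl on an aromatic carbon.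

A single measured step bears on this change: an 8.6-fold lower number from compound 1 to compound 2 (0.93 log units; beyond the scatter), a modest one, in which 2H-tetrazol-5-yl took the place of (cyclopropylamino)methyl on the same carbon. Here the 2H-tetrazol-5-yl leaves again, but a different group enters, so that one step is only a rough guide. Among the measured compounds shown here, no measured compound yet carries dimethylcarbamoyl. A partial return towards the higher number is therefore expected in this assay, of modest size and less than the full measured step. The estimated change is a 4.5-fold higher number from compound 2 to compound 3 (0.65 log units; beyond the scatter). Compound 3 is expected at 9000 nM, with an estimated range from 3000 nM to 30000 nM.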

Compound 3, half-maximal cytotoxic concentration: 25600 nM
For compound 3 the middle estimate is 2.8-fold (0.45 log units) below the measured one; measured number inside the range.
By their numbers in this assay, from the lowest: compound 2; then compounds 1 and 3 (each within the scatter of the next).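

In this assay, a 13-fold higher number from compound 2 to compound 3 (1.11 log units; beyond the scatter) is a large step that shows the lower number of compound 2 does not persist when 2H-tetrazol-5-yl gives way to dimethylcarbamoyl, a group of the same heavy-atom count. Among the compounds shown here, the a 1.5-fold higher number from compound 1 to compound 3 (0.17 log units; within the scatter) leaves compound 1 and compound 3 inseparable, so at this aromatic carbon dimethylcarbamoyl and (cyclopropylamino)methyl cannot be told apart, and among the three compounds only the one carrying 2H-tetrazol-5-yl stands apart. Nothing measured here explains why this carbon responds in this way.

The change from compound 2 to compound 3 removes a five-membered aromatic ring and a hydrogen-bond donor together, and the compounds shown leave open which of these, if either, goes with the difference in number. On these data alone, it also remains open how a carboxylic acid, a primary carboxamide or a triazole ring at the same carbon would read out, and whether any of them would fall closer to compound 2 or to compound 3.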